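Arylsulfanyl variation on a shared core: next heteroaryl step

The compounds below may be only part of what the source reports. "The series", "measured", "known", "first", "only" and "open" are said of these compounds alone.

Measured compounds:
compound 1 `C=C1CC[C@@H]2[C@](C)(CO)[C@H](O)CC[C@@]2(C)[C@@H]1CC(Sc1ccccc1)C1=CCOC1=O` gives 14000 nM
compound 2 `C=C1CC[C@@H]2[C@](C)(CO)[C@H](O)CC[C@@]2(C)[C@@H]1CC(Sc1cccs1)C1=CCOC1=O` gives 15000 nM
compound 3 `C=C1CC[C@@H]2[C@](C)(CO)[C@H](O)CC[C@@]2(C)[C@@H]1CC(Sc1ccccn1)C1=CCOC1=O` gives 18000 nM

In a functional assay on PC-3 cells (Homo sapiens) for inhibition, read by MTT assay, with a stated time of 48 h (on this read-out higher numbers stand for weaker inhibition and lower numbers for stronger inhibition), compound 3 gives 18000 nM, the highest of the three numbers, yet every step to it lies within the scatter: a 1.3-fold higher number from compound 1 to compound 3 (0.11 log units; within the scatter) and a 1.2-fold higher number from compound 2 to compound 3 (0.08 log units; within the scatter). The three aryl groups on sulfur are therefore indistinguishable on these data.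

Compound 4 `C=C1CC[C@@H]2[C@](C)(CO)[C@H](O)CC[C@@]2(C)[C@@H]1CC(Sc1ncccn1)C1=CCOC1=O` carries the change (pyrimidin-2-yl in place of pyridin-2-yl on a sulfur). For the measured compounds named here, the steps that bear on it are the two heteroaryl-for-aryl swaps already seen, a 1.1-fold higher number from compound 1 to compound 2 (0.03 log units; within the scatter) and a 1.2-fold higher number from compound 2 to compound 3 (0.08 log units; within the scatter), both within the scatter. A further exchange of one ring for another on the same sulfur is expected to give no step beyond the scatter, no change at the digits printed from compound 3 to compound 4 (within the scatter). Compound 4 is expected at 18000 nM, with a range of 9000 nM to 36000 nM.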

Compound 4, half-maximal inhibitory concentration: 7000 nM
Compound 4: the middle estimate sits 2.6-fold (0.41 log units) above what was measured; measured number below the stated range.
By their numbers in this assay, from the lowest: compounds 4, 1, 2 and 3 (each within the scatter of the next, the first and the last beyond it).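

In this assay, for the compounds shown here, the ring on this sulfur is no longer silent: pyrimidin-2-yl gives a 2.6-fold lower number from compound 3 to compound 4 (0.41 log units; beyond the scatter) and a 2.1-fold lower number from compound 2 to compound 4 (0.33 log units; beyond the scatter) as the first steps here beyond the scatter, while a 2.0-fold lower number from compound 1 to compound 4 (0.30 log units; within the scatter) stays within it. The position therefore responds modestly to the ring, but the separation from phenyl remains unresolved. Nothing available explains this difference.

Open, going by these compounds, is whether an amino group on the pyrimidin-2-yl ring, or a 1,3,5-triazin-2-yl ring in its place, would move the number further.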